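Adding a Second Methoxy Group Next to the First

A few compounds are considered here, and "the series" means these few. Any claim that something is new, unique, unknown or untested is made for them only; others in the source may bear on it.

Compound 1 `O=C(/C=C\Nc1ccc(F)cc1)c1nc(-c2ccc(F)cc2)n2ccccc12` gives 16900 nM in a functional assay on BT-474 cells (Homo sapiens) for cytotoxicity, read by MTT assay, with a stated time of 48 h; a lower number here means a stronger inhibitor, a higher number a weaker inhibitor. Compound 2 `COc1ccc(N/C=C\C(=O)c2nc(-c3ccc(F)cc3)n3ccccc23)cc1` gives 15700 nM in this assay.

Only these two numbers are known. Compound 2 and compound 1 lie within the scatter of each other, the step being a 1.1-fold lower number from compound 1 to compound 2 (0.03 log units; within the scatter), a methoxy in place of fluoro on an aromatic carbon. Neither number can be called the stronger.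

Compound 3 `COc1ccc(N/C=C\C(=O)c2nc(-c3ccc(F)cc3)n3ccccc23)cc1OC` differs from compound 2 by methoxy in place of hydrogen on an aromatic carbon. For the measured compounds named here, the one measured step that bears on this is the exchange from compound 1 to compound 2, which also changed a substituent on the same aromatic ring and brought a methoxy group in; it was within the scatter. A second methoxy group on that ring is a smaller change than replacing fluoro, so no step beyond the scatter is expected in this assay, in either direction. Compound 3 is therefore expected to give about 14000 nM, with a range from 6000 nM to 35000 nM. That expectation corresponds to a step of a 1.1-fold lower number from compound 2 to compound 3 (0.05 log units; within the scatter).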

Compound 3, half-maximal inhibitory concentration: > 30000 nM
Compound 3: a limit, no number; the forecaster's own chance of this, stated with the estimate: 5%; middle value at least 2.1-fold (0.33 log units) away from the limit.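

Compound 3 alone among the three carries a limit and not a number: the limit of > 30000 nM in this assay, at which 1 of the 3 values shown sits.

With that limit, the second methoxy group, ortho to the first and meta to a large group, gives an at least 1.9-fold higher number from compound 2 to compound 3 (0.28 log units; that floor lies within the scatter), and the full change from 4-fluorophenyl to 3,4-dimethoxyphenyl on the amine nitrogen gives an at least 1.7-fold higher number from compound 1 to compound 3 (0.24 log units; that floor lies within the scatter). The earlier pair showed only that exchanging one substituent on this ring for another left the number within the scatter, whereas this result shows that adding a methoxy group at this further position brings no lower number in this assay and may raise it, although both floors lie within the scatter and so neither step can be called a real loss.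

For the compounds shown here, how far the true value of compound 3 lies past its limit, and so whether the step from the single methoxy group exceeds the scatter, stays open. Going by these compounds, it is also open whether a hydroxy group, an amine or a carboxylic acid in this same place, ortho to the methoxy group, would give a readable number in this assay.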